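The source may hold more compounds than are shown below. What is called first, only, known or untested is meant among the compounds shown, and "the series" means these compounds.

Measured in an ADME assay on HCT-116 cells (Homo sapiens) for cytotoxicity, read by CellTiter-Glo, with a stated time of 72 h; on this read-out higher numbers stand for weaker inhibition and lower numbers for stronger inhibition:
Compound 1 `CC1CCN(C2CCN(S(=O)(=O)c3cccc(N)c3)CC2)CC1`: > 5000 nM (a limit)
Compound 2 `CC1CCN(C2CCN(S(=O)(=O)c3cnc(Cl)s3)CC2)CC1`: > 10000 nM (a limit)

Compound 2 therefore stands at a limit in this assay, with no exact number. Compound 3 `Cc1ccc(S(=O)(=O)N2CCC(N3CCC(C)CC3)CC2)cc1C` carries 3,4-dimethylphenyl in place of 2-chloro-1,3-thiazol-5-yl on a sulfonyl sulfur. Among the compounds with values here, the only measured step that bears on this change, a step that the two limits leave unreadable from compound 1 to compound 2, has no readable size and so gives no direction. Neither measured compound reaches a number, so no change beyond the usual scatter is expected. The expected step is a number no higher from compound 2 to compound 3 (the limit leaves the size open). Compound 3 is estimated at 10000 nM, within a range of 3000 nM to 30000 nM.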

Compound 3, half-maximal inhibitory concentration: > 5000 nM
Compound 3: only a limit was reported; the forecaster's own chance of this, stated with the estimate: 75%; the middle value is on the limit's open side.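

In this assay, within the data shown here, compound 1, compound 2 and compound 3 all stand at limits, not numbers, and no step between them can be read. Going by these compounds, whether changing the group on the sulfonyl sulfur shifts cytotoxicity stays open.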